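The source may report more compounds than this note shows. Statements on the series, on what has been measured and on what is new or still open speak of the compounds shown alone.

Working notes on the series. Compound 2 `Cc1nc(CN2CCC[C@H]2c2ccccn2)cc(N2CCN(C)CC2)n1` is the S-configured form of the racemate compound 1 `Cc1nc(CN2CCCC2c2ccccn2)cc(N2CCN(C)CC2)n1`. In an assay on HPBALL cells for binding affinity to C-X-C chemokine receptor type 4 (Homo sapiens), read by flow cytometry, with a stated time of 3 h (on this read-out lower numbers stand for stronger inhibition and higher numbers for weaker inhibition), compound 1 gives 319 nM, and compound 2 gives 220 nM; the two values lie within the scatter of each other, so the step of a 1.5-fold lower number from compound 1 to compound 2 (0.16 log units; within the scatter) is not read as a change. Compound 3 `Cc1nc(CN2CCC[C@@H]2c2ccccn2)cc(N2CCN(C)CC2)n1` is the R-configured form. For compound 3 this assay reports only a limit, > 10000 nM. The steps of an at least 31-fold higher number from compound 1 to compound 3 (1.49 log units; beyond the scatter) and an at least 45-fold higher number from compound 2 to compound 3 (1.65 log units; beyond the scatter) are both large, and for the second of them the only difference is the configuration at the saturated ring carbon (the fact that compounds 2 and 3 differ only in the configuration as drawn).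

Compound 4 `Cc1ccnc([C@@H]2CCCN2Cc2cc(N3CCN(C)CC3)nc(C)n2)c1` keeps the S configuration of compound 2 and differs from it only at the ring carrying the pyridin-2-yl group: methyl in place of hydrogen on an aromatic carbon. Among the measured compounds shown here, none of the measured steps touches this place; all three concern the stereocentre alone, so they say nothing about a methyl on the aromatic ring. In the absence of a measured step at this position, the expectation for compound 4 is a step in this assay of no more than the scatter, a 1.1-fold higher number from compound 2 to compound 4 (0.06 log units; within the scatter), in either direction. Compound 4 is accordingly estimated at 250 nM, with a range from 80 nM to 800 nM.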

Compound 4, half-maximal inhibitory concentration: 216 nM
For compound 4 the middle estimate is 1.2-fold (0.06 log units) above the measured one; low and high end bracket the measured number.
By their numbers in this assay, from the lowest: compounds 4, 2 and 1 (each within the scatter of the next). At a limit, above all of these: compound 3.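

In this assay the change from pyridin-2-yl to 4-methylpyridin-2-yl, with the S configuration kept, gives a 1.0-fold lower number from compound 2 to compound 4 (0.01 log units; within the scatter), so the two compounds cannot be told apart on this read-out. Among the compounds shown here, this is the first reading at the aromatic ring rather than at the stereocentre: methyl in place of hydrogen on the aromatic carbon opposite the ring nitrogen leaves no readable mark here, whereas the configuration at the saturated ring carbon was the only change so far seen to matter. Nothing in the data on this series bears on why the methyl makes no readable difference.

Going by these compounds, what an ethyl chain, a methoxy group, an amine or a carboxylic acid would give on this same aromatic carbon remains open, as does the effect of a methyl on the other aromatic carbons of this ring. For the compounds shown here, also open is whether the methyl reads the same way on the R-configured form, compound 3, since the single step here covers one group at one place on the S form alone.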